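Changing the aryl on the chain of compound 1

A few compounds are considered here, and "the series" means these few. Any claim that something is new, unique, unknown or untested is made for them only; others in the source may bear on it.

Measured so far:
compound 1 `COc1ccc(/C=C/C(=O)Nc2cc3c(Nc4ccc(F)c(Cl)c4)ncnc3cc2OC)c(OC)c1` — 38500 nM in a functional assay on PC-3 cells (Homo sapiens) for cytotoxicity, read by MTT assay, with a stated time of 72 h; a higher number here means a weaker inhibitor, a lower number a stronger inhibitor
compound 2 `COc1ccc(/C=C/C(=O)Nc2cc3c(Nc4ccc(F)c(Cl)c4)ncnc3cc2O[C@H]2CCOC2)c(OC)c1` — 2760 nM in this assay

Compound 1 stands highest of the two numbers; its nearest neighbour is compound 2, reached by a 14-fold lower number from compound 1 to compound 2 (1.14 log units; beyond the scatter). Compound 3 `COc1cc2ncnc(Nc3ccc(F)c(Cl)c3)c2cc1NC(=O)/C=C/c1cc(OC)c(OC)c(OC)c1` differs from compound 1 by 3,4,5-trimethoxyphenyl in place of 2,4-dimethoxyphenyl on a double-bonded chain carbon bound to a double-bonded chain carbon. Among the measured compounds shown here, the one measured step replaces a methyl on an oxygen on an aromatic ring, not the aryl on the chain, so no measured step bears on this change. With nothing to guide it, no shift beyond the scatter is expected, and the range is kept wide. Compound 3 is estimated at 25000 nM (range 8000 nM to 80000 nM), which means an expected 1.5-fold lower number from compound 1 to compound 3 (0.19 log units; within the scatter).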

Compound 3, half-maximal inhibitory concentration: 38200 nM
For compound 3 the middle estimate is 1.5-fold (0.18 log units) below the measured one, and the stated range covers the measured number.
By their numbers in this assay, from the lowest: compound 2; then compounds 3 and 1 (each within the scatter of the next).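

In this assay, among the compounds shown here, 3,4,5-trimethoxyphenyl in place of 2,4-dimethoxyphenyl on a double-bonded chain carbon bound to a double-bonded chain carbon gives a 1.0-fold lower number from compound 1 to compound 3 (0.00 log units; within the scatter) and is the first reading at this position. For the compounds shown here, these two aryl groups are not told apart here, whereas the one earlier step, made at the oxygen on the core, gave a 14-fold lower number from compound 1 to compound 2 (1.14 log units; beyond the scatter). No measured evidence bears on this result.

Open, on these data alone, is whether a dimethylamino group or a carboxylic acid on the aryl would move the number. Also open, as far as these compounds go, is whether the oxolan-3-yl step holds with 3,4,5-trimethoxyphenyl on the chain.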